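A few compounds are considered here, and "the series" means these few. Any claim that something is new, unique, unknown or untested is made for them only; others in the source may bear on it.

Measured compounds:
- compound 1 `Cc1cc(Cl)nc(NC(=S)NC(=O)c2c(-c3ccc(Cl)cc3Cl)noc2C)n1`: -6.84%
- compound 2 `Cc1onc(-c2ccc(Cl)cc2Cl)c1C(=O)/N=c1/nc2nc(Cl)cc(C)n2s1`: 25.8%

In a functional assay on the whole organism (strain L.) for inhibition, with Echinochloa crus-galli as the target, with a stated time of 72 h, tested at 10 mg/L (on this read-out lower numbers stand for less inhibition of growth and higher numbers for more inhibition of growth at the one concentration tested), compound 2 stands highest of the two numbers; compound 1 lies lower by a gap beyond the usual scatter. Compound 3 `COc1cc(Cl)nc2n/c(=N/C(=O)c3c(-c4ccc(Cl)cc4Cl)noc3C)sn12` differs from compound 2 by methoxy in place of methyl on an aromatic carbon. Among the measured compounds shown here, no measured pair shows this kind of change, so nothing is known about its effect; a step no larger than the scatter, in either direction, is expected. The expected step from compound 2 to compound 3 is a number 0.8 percentage points lower from compound 2 to compound 3 (within the scatter). Compound 3 is estimated to give 25%, within a range from 5% to 45%.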

Compound 3, percent growth inhibition at one concentration: 10.8%
Compound 3: the middle estimate sits 14.2 percentage points above what was measured; the measured number falls inside the stated range.
By their numbers in this assay, from the lowest: compound 1; then compound 3; then compound 2.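

In this assay this position proves sensitive: methoxy in place of methyl on this aromatic carbon gives a number 15 percentage points lower from compound 2 to compound 3 (beyond the scatter) and growth inhibition falls. A single small change here is therefore enough to move the result while the rest of the structure stays the same. No measurement shown explains the fall.

From the compounds shown here alone, how an amine or an ethyl chain at this position would compare stays open. One pair also cannot show whether the same swap would act alike on another core.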